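Adding a second chloro to the ortho-substituted purine series

The compounds below may be only part of what the source reports. "The series", "measured", "known", "first", "only" and "open" are said of these compounds alone.

Of the compounds shown here, two of this set have been measured in a functional assay on Hs-578T cells (Homo sapiens) for cytotoxicity, read by sulforhodamine B assay, with a stated time of 48 h; on this read-out higher numbers stand for weaker inhibition of growth and lower numbers for stronger inhibition of growth. Compound 1 `ClCc1ccc(Cn2cnc3c(Cl)ncnc32)cc1` gives 10200 nM in this assay. Compound 2 `ClCc1ccccc1Cn1cnc2ncnc(Cl)c21` gives 2290 nM in this assay, the lowest of the two numbers; the nearest number, that of compound 1, is higher by a margin beyond the usual scatter. Compound 3 `ClCc1ccccc1Cn1cnc2nc(Cl)nc(Cl)c21` has not been measured. It differs from compound 2 by chloro in place of hydrogen on an aromatic carbon. For the measured compounds named here, no measured pair in this set shows the effect of such a change, so the size of the step is open; the change adds one heavy atom and keeps the rest of the structure. In this assay compound 3 is expected to give a number close to that of compound 2, with a step of a 1.1-fold lower number from compound 2 to compound 3 (0.06 log units; within the scatter) that may well stay within the scatter. The estimate for compound 3 is 2000 nM, with a range from 600 nM to 7000 nM.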

Compound 3, concentration for 50% growth inhibition: 670 nM
Estimate against measurement, compound 3: 3.0-fold (0.47 log units) above; low and high end bracket the measured number.
By their numbers in this assay, from the lowest: compound 3; then compound 2; then compound 1.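

In this assay, chloro in place of hydrogen on an aromatic carbon, between two ring nitrogen atoms, gives a 3.4-fold lower number from compound 2 to compound 3 (0.53 log units; beyond the scatter), a modest step. For the compounds shown here, this is the one pair in the set that differs in a single place, and it shows that this position responds to the addition of one heavy atom, with the number moving towards stronger inhibition of growth. The data shown offer no measurement that would account for this step.

The compounds shown leave open whether an amine, a methoxy group or a fluoro at this place would move the number in the same direction, and by how much. They also leave open whether the same chloro would produce a similar step on compound 1, whose core carries the chloromethyl group at a different place.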